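This account rests on a few compounds, and the source may have more. Where it says the series, first, only, none or still open, it means among the compounds named here.

Measured so far in a physicochemical assay for acid dissociation:
- compound 1 `COc1ccc(F)cc1CNCCCNc1ccnc2cc(Cc3ccc(F)cc3Cl)ccc12`: 9.47
- compound 2 `COc1ccc(-c2ccc3c(NCCCNCc4cc(F)ccc4OC)ccnc3c2)cc1`: 9.47
- compound 3 `COc1ccc(F)cc1CNCCCNc1ccnc2cc(Oc3ccc(C(C)(C)C)cc3)ccc12`: 9.28

These three numbers lie within the scatter of one another, so compound 3, at 9.28, cannot be told apart from the other two.

Compound 4 `COc1ccc(F)cc1CNCCCNc1ccnc2cc(Oc3ccccc3)ccc12` differs from compound 3 in one place: hydrogen in place of tert-butyl on an aromatic carbon. This puts hydrogen in place of tert-butyl on an aromatic carbon, para to a large group.

Among the measured compounds shown here, no measured step makes this exact change, so the evidence is indirect. Three steps exchange a whole group on an aromatic carbon, and each stays within the scatter: no change at the digits printed from compound 1 to compound 2 (within the scatter), a number 0.19 log units lower from compound 1 to compound 3 (within the scatter) and a number 0.19 log units lower from compound 2 to compound 3 (within the scatter). Removing only the tert-butyl is a smaller edit than any of these whole-group exchanges, so no shift beyond the scatter is expected.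

The expected step is a number 0.02 log units higher from compound 3 to compound 4 (within the scatter).

For compound 4 the estimated value is 9.3, with an expected range from 9 to 9.6.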

Compound 4, acid dissociation constant: 9.28
Estimate against measurement, compound 4: 0.02 log units above, within the range that was stated.
By their numbers in this assay, from the lowest: compounds 3, 4, 1 and 2 (each within the scatter of the next).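

In this assay, among the compounds shown here, replacing tert-butyl with hydrogen on this aromatic carbon, para to a large group, gives no change at the digits printed from compound 3 to compound 4 (within the scatter); this is the first direct reading of that edit, and it shows that the whole tert-butyl can go without a shift that stands out from the scatter. The unsubstituted phenoxy group also cannot be told apart from the other two groups at this position, with a number 0.19 log units lower from compound 2 to compound 4 (within the scatter) and a number 0.19 log units lower from compound 1 to compound 4 (within the scatter). The data shown offer no independent measurement that could explain this flat picture.

Going by these compounds, it remains open whether an amine or a carboxylic acid on the phenoxy ring would also stay within the scatter. The effect of a longer chain in place of the side chain shared by all four compounds is open as well.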